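Piperidin-1-yl for pyrrolidin-1-yl on a shared core

A few compounds are considered here, and "the series" means these few. Any claim that something is new, unique, unknown or untested is made for them only; others in the source may bear on it.

In a functional assay on Hs 683 cells (Homo sapiens) for cytotoxicity, read by MTT assay, with a stated time of 72 h (on this read-out higher numbers stand for weaker inhibition and lower numbers for stronger inhibition), compound 1 `CSc1nc(Br)c(C(=O)c2ccccc2)s1` gives > 100000 nM as a limit of the assay, not a number. Compound 2 `COC(=O)c1sc2nc(SC)sc2c1C` reads 79000 nM and compound 3 `COC(=O)c1sc2nc(N3CCCC3)sc2c1C` reads 91000 nM here, so compound 3 stands level with compound 2 within the scatter. Going by the values given here, the only measured change at this place, pyrrolidin-1-yl in place of methylsulfanyl on an aromatic carbon, gave a 1.2-fold higher number from compound 2 to compound 3 (0.06 log units; within the scatter) and so suggests little sensitivity to the group there. Compound 4 `COC(=O)c1sc2nc(N3CCCCC3)sc2c1C` carries piperidin-1-yl in place of pyrrolidin-1-yl (piperidin-1-yl in place of pyrrolidin-1-yl on an aromatic carbon) on the same core. So a 1.1-fold lower number from compound 3 to compound 4 (0.03 log units; within the scatter) is what is expected in this assay and this is no step beyond the scatter. For compound 4 the estimated value is 85000 nM with an expected range between 45000 nM and 150000 nM in this measurement.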

Compound 4, half-maximal inhibitory concentration: > 100000 nM
Compound 4 was reported as a limit (the forecaster's own chance of this, stated with the estimate: 30%); middle value at least 1.1-fold (0.07 log units) from the limit.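

The value of compound 4 is a limit of the assay, not a true number. Going by these compounds, its steps are therefore only floors, an at least 1.0-fold higher number from compound 3 to compound 4 (0.04 log units; that floor lies within the scatter) and an at least 1.2-fold higher number from compound 2 to compound 4 (0.10 log units; that floor lies within the scatter), so swapping in piperidin-1-yl at this position brings no stronger inhibition into view, and the true size of the change stays unknown. The top of the measurable range can hide differences among these compounds: the limit of > 100000 nM in this assay, at which 2 of the 4 values shown sit.

On these data alone, it remains open whether an open-chain amine, a carboxylic acid or a longer chain at this position would lower the number.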